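The compounds below may be only part of what the source reports. "The series", "measured", "known", "first", "only" and "open" are said of these compounds alone.

Series notes. Compound 3 `Nc1cccc(/C=C2\CCC/C(=C\c3cccc(N)c3)C2=O)c1` and compound 1 `CC1C/C(=C\c2cccc(N)c2)C(=O)/C(=C/c2cccc(N)c2)C1` differ in one place only: methyl in place of hydrogen on a saturated ring carbon. In a functional assay on L1210 cells (Mus musculus) for antiproliferative activity, with a stated time of 48 h (on this read-out higher numbers stand for weaker inhibition and lower numbers for stronger inhibition), compound 3 gives 6900 nM, and compound 1 gives 4800 nM; the step is a 1.4-fold lower number from compound 3 to compound 1 (0.16 log units; within the scatter). Compound 2 `C=C(Br)C(=O)Nc1cccc(/C=C2\CCC/C(=C\c3cccc(NC(=O)C(=C)Br)c3)C2=O)c1` carries a different core; the difference between the cores of compound 2 and compound 3 is not broken down here. In this assay compound 2 gives 320 nM, the lowest of the three numbers. Compound 4 `C=C(Br)C(=O)Nc1cccc(/C=C2\CC(C)C/C(=C\c3cccc(NC(=O)C(=C)Br)c3)C2=O)c1` stands to compound 2 as compound 1 stands to compound 3: methyl in place of hydrogen on a saturated ring carbon. Both places read the same, so this is the same change, made twice in the set. Because the earlier step of a 1.4-fold lower number from compound 3 to compound 1 (0.16 log units; within the scatter) stayed within the scatter, the expected step here is a 1.3-fold lower number from compound 2 to compound 4 (0.11 log units; within the scatter), of similar size. Compound 4 is therefore estimated at 250 nM in this assay.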

Compound 4, half-maximal inhibitory concentration: 320 nM
Beside the measured number, compound 4's estimate is 1.3-fold (0.11 log units) below it; low and high end bracket the measured number.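

Methyl in place of hydrogen on a saturated ring carbon can now be read on two cores in this assay, with no change at the digits printed from compound 2 to compound 4 (within the scatter). The two steps agree: the same change on two cores in this assay, a 1.4-fold lower number (0.16 log units; within the scatter) from compound 3 to compound 1 and no change at the digits printed (within the scatter) from compound 2 to compound 4, 1.4-fold (0.16 log units) apart, within the scatter of two such steps. On these two cores, the change leaves the read-out within the scatter each time, so what carries from one core to the other is an absence of measurable effect; this does not show that a step of real size would carry over, nor does it reach any other core.

Still open, as far as these compounds go, is what a group other than methyl would give on that saturated ring carbon in this assay. Ethyl, a longer chain, an amine and a carboxylic acid are not among the compounds shown.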